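Dropping one methoxy group from compound 3

The source may report more compounds than this note shows. Statements on the series, on what has been measured and on what is new or still open speak of the compounds shown alone.

In an assay on HL-60 cells for inhibition of glutathione S-transferase P (Homo sapiens), read by spectrophotometry, tested at 20 uM (a lower number here means less inhibition, a higher number more inhibition at the concentration tested (going by the name of the read-out)), compound 1 `Cc1ccc2c(c1)C(=O)/C(=C/c1ccccc1)CN2CC(=O)O` gives 4.23%, compound 2 `Cc1ccc2c(c1)C(=O)/C(=C/c1ccc(Br)cc1)CN2CC(=O)O` gives 28.2%, and compound 3 `COc1cc(/C=C2\CN(CC(=O)O)c3ccc(C)cc3C2=O)cc(OC)c1` gives 23.8%. Compound 3 therefore stands second highest of the three numbers: its value and that of compound 2 lie within the scatter of one another, while compound 1 sits clearly lower. Among the measured compounds shown here, the one single-point step measured so far is a number 24 percentage points higher from compound 1 to compound 2 (beyond the scatter), which shows that a substituent on the distal aromatic ring can move the read-out beyond the scatter. Compound 4 `COc1cccc(/C=C2\CN(CC(=O)O)c3ccc(C)cc3C2=O)c1` differs from compound 3 by hydrogen in place of methoxy on an aromatic carbon; the hydrogen enters at a position meta to a large group and meta to a methoxy group. For the measured compounds named here, no measured pair probes the loss of a methoxy group directly, so the expectation rests on compound 1, which carries no substituent on that ring and gives 4.23%, and on compound 3 with two methoxy groups giving 23.8%. With one methoxy group remaining, compound 4 is expected to fall between these, so the estimated step is a number 8.8 percentage points lower from compound 3 to compound 4 (within the scatter). Compound 4 is thus estimated at 15%, within a range from 5% to 28%.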

Compound 4, a percentage reported as inhibition, at one concentration (the size of the read-out at that concentration, not a potency): 14.4%
Estimate against measurement, compound 4: 0.6 percentage points above; the measured number falls inside the stated range.
By their numbers in this assay, from the lowest: compound 1; then compounds 4, 3 and 2 (each within the scatter of the next, the first and the last beyond it).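

In this assay, a single methoxy group already counts: the step is a number 10.2 percentage points higher from compound 1 to compound 4 (beyond the scatter), so one methoxy group is enough to move the read-out beyond the scatter. Taking away the other methoxy group gives a number 9.4 percentage points lower from compound 3 to compound 4 (within the scatter), which means that the second group adds nothing that can be told apart from the scatter. Exchanging 4-bromophenyl for 3-methoxyphenyl gives a number 13.8 percentage points lower from compound 2 to compound 4 (beyond the scatter), so a single methoxy group does not match the bromo compound in this assay.

On these data alone, whether a hydroxy group or an amine on this aromatic carbon would give a read-out like that of methoxy remains open. Nothing available explains the size of these steps.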